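This account rests on a few compounds, and the source may have more. Where it says the series, first, only, none or still open, it means among the compounds named here.

Compound 1 `O=c1cc(CSC(=S)N2CCCCC2)oc2cc(Cl)ccc12` carries a piperidin-1-yl group on a thiocarbonyl carbon whose other neighbour is sulfur, attached to a chloro-bearing core. In a functional assay on MCF7 cells (Homo sapiens) for antiproliferative activity, read by MTT assay, with a stated time of 72 h (a higher number here means a weaker inhibitor, a lower number a stronger inhibitor), compound 1 reaches only the limit of the test, recorded as > 25000 nM. Compound 2 `O=c1cc(CSC(=S)N2CCCCC2)oc2ccccc12` differs from compound 1 by a hydrogen in place of the chloro on an aromatic carbon. In this assay compound 2 likewise stops at the limit, recorded as > 25000 nM. The step that the two limits leave unreadable from compound 1 to compound 2 therefore cannot be read in size because of the limit of > 25000 nM in this assay, at which 2 of the 2 values shown sit. Compound 3 `CC(C)N(C(=S)SCc1cc(=O)c2ccc(Cl)cc2o1)C(C)C` arises from compound 1 through the change (diisopropylamino in place of piperidin-1-yl on a thiocarbonyl carbon). Within the data shown here, no measured step touches the substituent on the thiocarbonyl carbon, so the only guide available is that both measured compounds sit at the limit without a readable number between them. With that guide the step that the limit leaves unreadable from compound 1 to compound 3 is expected to be small, and the result is expected most likely to remain a limit rather than a number. Compound 3 is therefore estimated at 30000 nM in this assay, with a range from 10000 nM to 100000 nM.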

Compound 3, half-maximal inhibitory concentration: > 25000 nM
Compound 3: a limit, no number (the forecaster's own chance of this, stated with the estimate: 75%); the middle value does not contradict the limit.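

In this assay, no size can be read for the step from compound 1 to compound 3, because both compounds give only a limit and not a number: the limit of > 25000 nM in this assay, at which 3 of the 3 values shown sit.

The compounds shown leave open whether changing the chloro or the group on the thiocarbonyl carbon alters antiproliferative activity at all, and which change might yield a measurable number.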